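Arylpiperazine swap in a sulfonyl-isoindolinone series

The source may report more compounds than this note shows. Statements on the series, on what has been measured and on what is new or still open speak of the compounds shown alone.

Compound 1 `O=C1c2ccccc2S(=O)(=O)N1CCCCCCN1CCN(c2ccc(Cl)c(Cl)c2)CC1` gives 132 nM in an ADME assay on HEK293 cells for displacement of a labelled ligand from 5-hydroxytryptamine receptor 6 (Homo sapiens), read by radioligand binding, with a stated time of 1 h; on this read-out higher numbers stand for weaker inhibition and lower numbers for stronger inhibition. Compound 2 `O=C1c2ccccc2S(=O)(=O)N1CCCCCCN1CCN(c2ccccn2)CC1` gives 2350 nM in this assay, the highest of the two numbers; the step of an 18-fold higher number from compound 1 to compound 2 (1.25 log units; beyond the scatter) was large. Compound 3 `O=C1c2ccccc2S(=O)(=O)N1CCCCCCN1CCN(c2ncccn2)CC1` carries the change (pyrimidin-2-yl in place of pyridin-2-yl on an amine nitrogen in a ring). No measured step covers a change among heteroaryl groups on this ring nitrogen; the only step shown concerns a different exchange and cannot be carried over. He therefore expects, for compound 3, a step of a 1.3-fold higher number from compound 2 to compound 3 (0.11 log units; within the scatter) not beyond the scatter. The estimate for compound 3 in this assay is 3000 nM, with a range from 1000 nM to 9000 nM.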

Compound 3, inhibition constant: 104 nM
Estimate against measurement, compound 3: 29-fold (1.46 log units) above, outside the stated range (below it).
By their numbers in this assay, from the lowest: compounds 3 and 1 (each within the scatter of the next); then compound 2.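

On the amine nitrogen in the ring, exchanging pyridin-2-yl for pyrimidin-2-yl gives a 23-fold lower number from compound 2 to compound 3 (1.35 log units; beyond the scatter) and so separates two groups of equal heavy-atom count, which shows that this position responds to a single ring-atom change. Pyrimidin-2-yl in place of 3,4-dichlorophenyl gives a 1.3-fold lower number from compound 1 to compound 3 (0.10 log units; within the scatter) and so shows that a number this low does not depend on the chlorine-bearing phenyl ring. Nothing available explains the large step from pyridin-2-yl.

As far as these compounds go, it remains open whether pyrazin-2-yl or unsubstituted phenyl on this nitrogen would stand with compound 3 or with compound 2. From the compounds shown here alone, it is also open whether the large step would persist with a shorter chain.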